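A few compounds are considered here, and "the series" means these few. Any claim that something is new, unique, unknown or untested is made for them only; others in the source may bear on it.

Measured so far:
compound 1 `CCCC[C@@H](CCn1cncn1)c1ccccc1`, 40.8 ug/mL
compound 2 `CCCC[C@@H](CCn1cncn1)c1ccc(F)cc1`, 36 ug/mL

In an ADME assay on HEp-2 cells (Homo sapiens) for cytotoxicity, read by MTT assay, with a stated time of 3 days (on this read-out lower numbers stand for higher toxicity in this test and higher numbers for lower toxicity in this test), compound 1 gives 40.8 ug/mL, the highest of the two numbers. Going by the values given here, compound 2 gives 36 ug/mL, and the one recorded step, a 1.1-fold lower number from compound 1 to compound 2 (0.05 log units; within the scatter), stays within the scatter. Compound 3 `c1ccc(C[C@@H](CCn2cncn2)c2ccccc2)cc1` differs from compound 1 by phenyl in place of propyl on a saturated chain carbon, two bonds along the chain from an aromatic carbon. Among the compounds with values here, no measured step covers this change; the only step known concerns a different change and was within the scatter, so no direction can be drawn from it. The step from compound 1 to compound 3 is therefore expected to be small, a 1.2-fold lower number from compound 1 to compound 3 (0.07 log units; within the scatter). Compound 3 is estimated at 35 ug/mL, between 14 ug/mL and 85 ug/mL.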

Compound 3, half-maximal cytotoxic concentration: 55.9 ug/mL
For compound 3 the middle estimate is 1.6-fold (0.20 log units) below the measured one; the measured number falls inside the stated range.
By their numbers in this assay, from the lowest: compounds 2, 1 and 3 (each within the scatter of the next).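

On a saturated chain carbon, two bonds along the chain from an aromatic carbon, phenyl in place of propyl gives a 1.4-fold higher number from compound 1 to compound 3 (0.14 log units; within the scatter) in this assay. This position therefore carries either propyl or phenyl, ring or no ring, with the two numbers staying within the scatter of each other. No evidence at hand bears on this result.

From the compounds shown here alone, whether an amine or a carboxylic acid at this place would give a step beyond the scatter stays open. So does the effect of a fluoro on the phenyl that enters in compound 3.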